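This account rests on a few compounds, and the source may have more. Where it says the series, first, only, none or still open, it means among the compounds named here.

Three compounds in this set have a measured value. Compound 1 `CNC(=O)c1cc(C(=O)NC2CCC2)cn(Cc2ccncc2)c1=O` gives 121 ug/mL in a physicochemical assay for solubility, read by HPLC, in simulated intestinal fluid, with a stated time of 16 h, tested at 125 ug/mL; on this read-out lower numbers stand for lower solubility and higher numbers for higher solubility. Compound 2 `CNC(=O)c1cc(C(=O)NC2CC2)cn(Cc2cccc(OC)c2)c1=O` gives 582 ug/mL, and compound 3 `CNC(=O)c1cc(C(=O)NC2CC2)cn(Cc2ccc3nc[nH]c3c2)c1=O` gives 225 ug/mL. Compound 3 therefore stands second of the three, with compound 1 within the scatter of it and compound 2 clearly higher: the step of a 2.6-fold lower number from compound 2 to compound 3 (0.41 log units; beyond the scatter) is beyond the scatter.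

Compound 4 `CNC(=O)c1cc(C(=O)NC2CC2)cn(Cc2cccc3cc[nH]c23)c1=O` has not yet been measured. It differs from compound 3 in one place: 1H-indol-7-yl in place of 1H-benzimidazol-6-yl on a saturated chain carbon bound to an aromatic nitrogen. Among the measured compounds shown here, only the step from compound 2 to compound 3 touches the same position, and it was modest, so the exchange of one aromatic two-ring group for another at that position has so far moved the number by a limited amount. With a single relevant step and no repeat of this exact exchange, the expectation for compound 4 is a small downward move or none beyond the scatter, expressed as a 1.3-fold lower number from compound 3 to compound 4 (0.10 log units; within the scatter). The estimate for compound 4 is 180 ug/mL, within a range from 70 ug/mL to 450 ug/mL.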

Compound 4, solubility: 11 ug/mL
Estimate against measurement, compound 4: 16-fold (1.21 log units) above; measured number below the stated range.
By their numbers in this assay, from the lowest: compound 4; then compounds 1 and 3 (each within the scatter of the next); then compound 2.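

In this assay, among the compounds shown here, this position turns out to be far more sensitive than the earlier compounds suggested: the first exchange there gave a 2.6-fold lower number from compound 2 to compound 3 (0.41 log units; beyond the scatter), while this one gives a 20-fold lower number from compound 3 to compound 4 (1.31 log units; beyond the scatter). Against the single-ring 3-methoxyphenyl group, 1H-indol-7-yl gives a 53-fold lower number from compound 2 to compound 4 (1.72 log units; beyond the scatter), so having two aromatic rings at this position does not by itself fix the number, as 1H-benzimidazol-6-yl and 1H-indol-7-yl have the same heavy-atom count and very different results. Nothing measured here accounts for the drop.

The exchange removes a ring nitrogen and moves the point of attachment at once, and the compounds shown cannot separate these two changes. They also leave open how the indole would read if it carried an added amine or carboxylic acid.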